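From Nitro to Amino: Estimating the Next Compound

The source may report more compounds than this note shows. Statements on the series, on what has been measured and on what is new or still open speak of the compounds shown alone.

Within the data shown here, compound 2 `CN(C)c1ccc(-c2cccc([N+](=O)[O-])c2)cc1` gives the lower of the two numbers measured so far: in an assay on COS-7 cells for inhibition of patatin-like phospholipase domain-containing protein 2 (Mus musculus), tested at 200 uM (a higher number here means more inhibition at the concentration tested (going by the name of the read-out), a lower number less inhibition), compound 2 gives 21%, while compound 1 `CCOC(=O)c1cccc(-c2ccc(N(C)C)cc2)c1` gives 87%. Among the measured compounds shown here, the single measured step, a number 66 percentage points lower from compound 1 to compound 2 (beyond the scatter), marks nitro in place of ethoxycarbonyl as a large drop. Compound 3 `CN(C)c1ccc(-c2cccc(N)c2)cc1` differs from compound 2 by amino in place of nitro on an aromatic carbon. For the measured compounds named here, no measured step compares amino with nitro, so the only guide is that the compound carrying nitro gave the lowest number in this assay. Compound 3 is therefore expected to give 35%, within 10% to 70%, an estimated change of a number 14 percentage points higher from compound 2 to compound 3 (beyond the scatter) with wide uncertainty.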

Compound 3, a percentage reported as inhibition, at one concentration (the size of the read-out at that concentration, not a potency): 70%
Compound 3: middle estimate off by 35 percentage points, on the low side; low and high end bracket the measured number.
By their numbers in this assay, from the lowest: compound 2; then compound 3; then compound 1.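

Amino in place of nitro on this aromatic carbon gives a number 49 percentage points higher from compound 2 to compound 3 (beyond the scatter) in this assay and shows that a small nitrogen-containing group here need not bring the low number seen with nitro. Amino in place of ethoxycarbonyl still gives a number 17 percentage points lower from compound 1 to compound 3 (beyond the scatter) and leaves ethoxycarbonyl with the highest number of the three. Nothing available explains why these groups differ.

Open, on these data alone, is how a carboxylic acid, an amide or a methylamino group at this position would compare. Also open, as far as these compounds go, is whether the order of these three groups would hold elsewhere on the shared core.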